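One Double Bond, Drawn Two Ways

A few compounds are considered here, and "the series" means these few. Any claim that something is new, unique, unknown or untested is made for them only; others in the source may bear on it.

In a functional assay on cells (Endothelial cell, Bos taurus) for antiproliferative activity (a higher number here means a weaker inhibitor, a lower number a stronger inhibitor), compound 1 (`COc1ccc(/C(F)=C/c2cc(OC)c(OC)c(OC)c2)cc1F`) gives 610000 nM and holds the second highest of three numbers. Compound 2 (`COc1ccc(/C(F)=C/c2cc(OC)c(OC)c(OC)c2)cc1N`) gives 111000 nM and stands lowest, while compound 3 (`COc1ccc(/C(F)=C(\F)c2cc(OC)c(OC)c(OC)c2)cc1[N+](=O)[O-]`) gives 2300000 nM and stands highest.

Compound 4 (`COc1ccc(/C(F)=C\c2cc(OC)c(OC)c(OC)c2)cc1F`) has not yet been measured. Its difference from compound 1 is the two compounds have the same atoms and bonds and differ only in configuration as drawn: 1 of 1 stereo elements differ; a double bond is drawn Z in compound 1 and E in compound 4 and nothing leaves or enters: a double bond is drawn Z in compound 1 and E in compound 4.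

For the measured compounds named here, only one measured step is available, a 5.5-fold lower number from compound 1 to compound 2 (0.74 log units; beyond the scatter) as amino replaces fluoro on an aromatic carbon. Going by the values given here, it does not touch configuration, and no measured pair differs in configuration alone, so the data fix neither the size nor the direction of this change. That step serves only as a rough gauge of how far single changes have moved the numbers here. Compound 1 gives 610000 nM and already lies towards the high end, so a lower number is tentatively expected, by a step somewhat larger than the gauge. The estimated step is a 15-fold lower number from compound 1 to compound 4 (1.18 log units; beyond the scatter) and it remains uncertain. For compound 4 the estimated value is 40000 nM within an expected range of 2000 nM to 500000 nM overall.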

Compound 4, half-maximal inhibitory concentration: 23000 nM
Beside the measured number, compound 4's estimate is 1.7-fold (0.24 log units) above it, and the stated range covers the measured number.
By their numbers in this assay, from the lowest: compound 4; then compound 2; then compound 1; then compound 3.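

In this assay, for the compounds shown here, turning the double bond from Z to E as drawn gives a 27-fold lower number from compound 1 to compound 4 (1.42 log units; beyond the scatter), and this is the first pair here in which configuration alone moves the number. That step is larger than a 5.5-fold lower number from compound 1 to compound 2 (0.74 log units; beyond the scatter), so of the two single changes that can be read from compound 1, the configuration of this double bond counts for more than amino in place of fluoro on an aromatic carbon. The whole shift can be placed on the double bond, because nothing else separates the two structures: the fact that compounds 1 and 4 differ only in the configuration as drawn

The compounds shown hold only one pair of this kind, so it stays open whether the same change of configuration would move the number as far, or in the same direction, with the amino group of compound 2 on the aromatic carbon. From the compounds shown here alone, how a chloro, hydroxy or nitrile group at that aromatic carbon would read with the double bond drawn E, as in compound 4, also stays open.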